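A few compounds are considered here, and "the series" means these few. Any claim that something is new, unique, unknown or untested is made for them only; others in the source may bear on it.

Compound 1, `CC#CC(CC(=O)O)c1ccc(OCC2COc3ccc(Cl)cc3O2)cc1`, and compound 2, `CC#C[C@@H](CC(=O)O)c1ccc(OC[C@H]2COc3ccc(C)cc3O2)cc1`, share a common core and differ in the substituent on the fused ring and in the stereochemistry written for them. In a functional assay on HEK293 cells for agonist activity at Free fatty acid receptor 1 (Homo sapiens), read by fluorescence and calcium flux, with a stated time of 10 min (a higher number here means that more compound is needed for the effect, a lower number that less compound is needed), compound 1 gives 100 nM. In this assay compound 2 gives 120 nM; this is the higher of the two numbers, yet the gap to compound 1 lies within the scatter, so the two values show no difference that can be read. Compound 3, `CC#C[C@@H](CC(=O)O)c1ccc(OC[C@H]2COc3ccc(C(=O)N(C)C)cc3O2)cc1`, is the compound that has not yet been measured. It differs from compound 2 in one place: dimethylcarbamoyl in place of methyl on an aromatic carbon. Going by the values given here, no step between measured compounds bears on such a change, so there is nothing to lean on other than the two values already given. A small step toward a higher number in this assay is expected, a 1.7-fold higher number from compound 2 to compound 3 (0.22 log units; within the scatter), with the possibility of no change beyond the scatter. For compound 3 the estimate in this assay is 200 nM, within a range from 60 nM to 700 nM.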

Compound 3, half-maximal effective concentration: > 30000 nM
Compound 3: no number, only a limit (the forecaster's own chance of this, stated with the estimate: 5%); middle value at least 150-fold (2.17 log units) from the limit.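

Compound 3 gives no number in this assay, only a limit of the assay: the limit of > 30000 nM in this assay, at which 1 of the 3 values shown sits. Dimethylcarbamoyl in place of methyl on this aromatic carbon, para to a fused ring, brings an at least 250-fold higher number from compound 2 to compound 3 (2.39 log units; beyond the scatter), so this position does not accept every group while the rest of compound 2 stays the same. The earlier compounds shown here offered no step at this place, and this first one is large and gives only a lower bound on the size of the change.

This single step cannot say whether the carbonyl, the two methyl groups on nitrogen or the larger count of heavy atoms matters most. On these data alone, how a primary carboxamide, a methoxy group or a nitrile at this place would read in this assay stays open.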